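The source may report more compounds than this note shows. Statements on the series, on what has been measured and on what is new or still open speak of the compounds shown alone.

Of the compounds shown here, three built on one shared core have been measured in an assay on isolated protein for inhibition of Amine oxidase [flavin-containing] B (Homo sapiens), read by fluorescence, with stated times of 15 min and 20 min; on this read-out lower numbers stand for stronger inhibition and higher numbers for weaker inhibition. Compound 1 `Cc1ccc(C2=NN(C(=O)CN3CCCCC3)C(c3ccccc3O)C2)cc1` gives 45600 nM there. Compound 2 `O=C(CN1CCCCC1)N1N=C(c2ccccc2)CC1c1ccccc1O` gives 50600 nM, and compound 3 `Cc1ccc(C2=NN(C(=O)Cn3ccnc3)C(c3ccccc3O)C2)cc1` gives 41300 nM. The number for compound 3 is the lowest of the three, yet its distance from either of the other two falls within the usual scatter of such measurements. The step of a 1.1-fold higher number from compound 1 to compound 2 (0.05 log units; within the scatter) and the step of a 1.1-fold lower number from compound 1 to compound 3 (0.04 log units; within the scatter) were both small.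

Compound 4 `O=C(Cn1ccnc1)N1N=C(c2ccccc2)CC1c1ccccc1O` has not yet been measured. It differs from compound 3 by hydrogen in place of methyl on an aromatic carbon, the same change that separates compound 1 from compound 2. That earlier step is the one that bears on the present one, and it stayed within the scatter. No shift beyond the scatter is therefore expected in this assay from this change. The expected step is a 1.1-fold higher number from compound 3 to compound 4 (0.04 log units; within the scatter). Compound 4 is estimated to give 45000 nM, with a range from 20000 nM to 95000 nM.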

Compound 4, half-maximal inhibitory concentration: 59400 nM
For compound 4 the middle estimate is 1.3-fold (0.12 log units) below the measured one; measured number inside the range.
By their numbers in this assay, from the lowest: compounds 3, 1, 2 and 4 (each within the scatter of the next).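

In this assay, the change from 4-methylphenyl to phenyl, now seen with 1H-imidazol-1-yl in place of piperidin-1-yl, gave a 1.4-fold higher number from compound 3 to compound 4 (0.16 log units; within the scatter), so this change stays within the scatter on both cores: the same change on two cores in this assay, a 1.1-fold higher number (0.05 log units; within the scatter) from compound 1 to compound 2 and a 1.4-fold higher number (0.16 log units; within the scatter) from compound 3 to compound 4, 1.3-fold (0.11 log units) apart, within the scatter of two such steps The exchange of piperidin-1-yl for 1H-imidazol-1-yl can now also be read without the methyl, where it gave a 1.2-fold higher number from compound 2 to compound 4 (0.07 log units; within the scatter), and it too agrees on both cores: the same change on two cores in this assay, a 1.1-fold lower number (0.04 log units; within the scatter) from compound 1 to compound 3 and a 1.2-fold higher number (0.07 log units; within the scatter) from compound 2 to compound 4, 1.3-fold (0.11 log units) apart, within the scatter of two such steps Neither of the two changes has therefore moved the number beyond the scatter on either core.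

Still open, as far as these compounds go, is whether a methoxy group, a chlorine or a carboxylic acid in the place of the methyl would shift the number beyond the scatter. The same question stands for a morpholine or a longer chain in the place of piperidin-1-yl.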